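Acetyl added to the bicyclic core of compound 3

The source may report more compounds than this note shows. Statements on the series, on what has been measured and on what is new or still open speak of the compounds shown alone.

Compound 1 `Oc1cc(F)ccc1C(c1ccc2ccoc2c1O)N1CCCCC1` gives 1070 nM in an assay for inhibition of protein disulfide-isomerase (Homo sapiens), with a stated time of 1 h; on this read-out lower numbers stand for stronger inhibition and higher numbers for weaker inhibition. Compound 2 `Cc1ccc(C(Nc2ccccn2)c2ccc3cccnc3c2O)cc1` gives 460 nM in this assay. Compound 3 `Oc1c(C(c2ccc(F)cc2)N2CCCCC2)ccc2ccoc12` gives 560 nM in this assay. Of the three numbers, compound 3 sits nearest compound 2, and the gap to compound 1 is also within the scatter; no order among the three can be read from these values. Within the data shown here, the only single-point step in the set, a 1.9-fold lower number from compound 1 to compound 3 (0.28 log units; within the scatter), concerns hydrogen in place of hydroxy on an aromatic carbon.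

Compound 4 `CC(=O)c1cc2ccc(C(c3ccc(F)cc3)N3CCCCC3)c(O)c2o1` differs from compound 3 by acetyl in place of hydrogen on an aromatic carbon. Among the measured compounds shown here, no measured pair carries an acetyl group or any substituent on that five-membered ring, so the step from compound 1 to compound 3 does not speak to this change, and nothing here points to a shift in either direction. Compound 4 is therefore expected to land close to compound 3, with no change at the digits printed from compound 3 to compound 4 (within the scatter) as the estimated step and a wide range. The estimate for compound 4 in this assay is 560 nM, expected between 180 nM and 1800 nM.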

Compound 4, half-maximal inhibitory concentration: 1230 nM
Compound 4: the middle estimate sits 2.2-fold (0.34 log units) below what was measured; the range from low to high includes it.
By their numbers in this assay, from the lowest: compounds 2, 3, 1 and 4 (each within the scatter of the next, the first and the last beyond it).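

Acetyl in place of hydrogen on an aromatic carbon of the five-membered aromatic ring, next to the ring oxygen, gives a 2.2-fold higher number from compound 3 to compound 4 (0.34 log units; beyond the scatter) in this assay, the first reading on any substituent at this position and the only step in the series printed as beyond the scatter. The step is modest, and compound 4 still gives a finite number at 1230 nM, so this position accepts acetyl with some weakening rather than a loss of the read-out. Nothing available explains the step.

One substituent cannot separate the effect of acetyl itself from that of any group at this carbon. Going by these compounds, whether methyl, a carboxylic acid or an amine at the same place moves the number in the same direction stays open, as does whether the step carries over to the core of compound 1.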